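Acyl change on the ring nitrogen of compound 2

The source may hold more compounds than are shown below. What is called first, only, known or untested is meant among the compounds shown, and "the series" means these compounds.

The series shares the core of compound 1 `COc1ccc(NC(=O)C2CCc3ccccc3N2)cc1`, an amide bearing a free ring nitrogen, which in a functional assay on ACHN cells (Homo sapiens) for cytotoxicity, read by sulforhodamine B assay, with a stated time of 72 h (on this read-out higher numbers stand for weaker inhibition of growth and lower numbers for stronger inhibition of growth), gives 38000 nM. Compound 3 `O=C(Nc1ccccc1O)C1CCc2ccccc2N1C(=O)c1ccc(Cl)cc1`, carrying a (4-chlorophenyl)carbonyl on that ring nitrogen and a 2-hydroxyphenyl on the amide, gives 19600 nM in this assay. Compound 2 `O=C(Nc1cc(C(F)(F)F)cc(C(F)(F)F)c1)C1CCc2ccccc2N1C(=O)c1ccccc1Cl`, with a (2-chlorophenyl)carbonyl on the ring nitrogen and a bis(trifluoromethyl)phenyl on the amide, gives 4700 nM in this assay, the lowest of the three numbers; its gap to compound 3 and its gap to compound 1 both lie beyond the scatter. The three compounds differ from one another in more than one place, so no single change can be read off from the measured values.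

Compound 4 `CCC(=O)N1c2ccccc2CCC1C(=O)Nc1cc(C(F)(F)F)cc(C(F)(F)F)c1` has not yet been measured in this assay. It differs from compound 2 in one place: ethyl in place of 2-chlorophenyl on a carbonyl carbon. Within the data shown here, no measured pair shows this change, so its size is unknown; the loss of the six-membered aromatic ring is expected to weaken growth inhibition modestly, an estimated step of a 2.6-fold higher number from compound 2 to compound 4 (0.41 log units; beyond the scatter), though a result within the scatter would not surprise. Compound 4 is expected to give about 12000 nM in this assay, in the range 4000 nM to 40000 nM.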

Compound 4, concentration for 50% growth inhibition: 7720 nM
For compound 4 the middle estimate is 1.6-fold (0.19 log units) above the measured one, and the stated range covers the measured number.
By their numbers in this assay, from the lowest: compounds 2 and 4 (each within the scatter of the next); then compounds 3 and 1 (each within the scatter of the next).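

In this assay, a 1.6-fold higher number from compound 2 to compound 4 (0.22 log units; within the scatter), so with the bis(trifluoromethyl)phenyl amide kept, compounds 2 and 4 cannot be told apart. Among these compounds, this is the first direct reading at this position: on a carbonyl carbon whose other neighbours are an amide-type nitrogen in a ring, the 2-chlorophenyl, with its six-membered aromatic ring and its chlorine, can give way to ethyl without a step beyond the scatter, which means that for this pair the aromatic ring is not needed to keep the number where it stands. No measurement on hand bears on why the two groups read alike.

This single pair leaves open whether the position stays as tolerant with a longer chain, a carboxylic acid or an amine carried on that carbonyl carbon, since only 2-chlorophenyl and ethyl have been read there with this amide. It also leaves open whether propanoyl would read the same way with another amide group, such as the 2-hydroxyphenyl of compound 3, and what the bare ring nitrogen would give with the bis(trifluoromethyl)phenyl amide in place.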